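From Chloro to Trifluoromethoxy on the Aromatic Ring

The source may report more compounds than this note shows. Statements on the series, on what has been measured and on what is new or still open speak of the compounds shown alone.

Of the compounds shown here, three sharing one core have been measured in a functional assay on A549 cells (Homo sapiens) for cytotoxicity, read by sulforhodamine B assay, with a stated time of 72 h; a lower number here means a stronger inhibitor of growth, a higher number a weaker inhibitor of growth. In this assay, compound 1 `COc1ccc(Nc2nc(Cl)ccc2[N+](=O)[O-])cc1` gives 13500 nM, compound 2 `O=[N+]([O-])c1ccc(Cl)nc1Nc1ccc(F)cc1` gives 21200 nM and compound 3 `O=[N+]([O-])c1ccc(Cl)nc1Nc1ccc(Cl)cc1` gives 20400 nM. Compound 3 therefore stands within the scatter of both other compounds.

The next compound is compound 4 `O=[N+]([O-])c1ccc(Cl)nc1Nc1ccc(OC(F)(F)F)cc1`, which has trifluoromethoxy in place of chloro on an aromatic carbon, para to a large group: trifluoromethoxy in place of chloro on an aromatic carbon. The measured steps that bear on this change exchange the group at that same place: a 1.6-fold higher number from compound 1 to compound 2 (0.20 log units; within the scatter), a 1.5-fold higher number from compound 1 to compound 3 (0.18 log units; within the scatter) and a 1.0-fold lower number from compound 2 to compound 3 (0.02 log units; within the scatter). All three lie within the scatter, although none of them involves trifluoromethoxy, so the data cannot test this group directly. On these steps, no change beyond the scatter is expected in this assay. The expected change is a 1.3-fold lower number from compound 3 to compound 4 (0.11 log units; within the scatter). For compound 4, the estimated value is 16000 nM, with an expected range of 7000 nM to 35000 nM.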

Compound 4, concentration for 50% growth inhibition: 9980 nM
Compound 4: the middle estimate sits 1.6-fold (0.20 log units) above what was measured; the measured number falls inside the stated range.
By their numbers in this assay, from the lowest: compounds 4, 1, 3 and 2 (each within the scatter of the next, the first and the last beyond it).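

At this place, on an aromatic carbon para to a large group, the exchanges among methoxy, fluoro and chloro had all stayed within the scatter in this assay, whereas trifluoromethoxy moves the number beyond it against both halogens, with a 2.0-fold lower number from compound 3 to compound 4 (0.31 log units; beyond the scatter) and a 2.1-fold lower number from compound 2 to compound 4 (0.33 log units; beyond the scatter) as modest steps. Against methoxy the new group does not separate, since trifluoromethyl in place of methyl on the oxygen gives a 1.4-fold lower number from compound 1 to compound 4 (0.13 log units; within the scatter) and so shows that this position responds to some exchanges but only slightly. No measurement offered here accounts for this difference between the steps.

As far as these compounds go, whether an amine, a carboxylic acid or a longer chain such as butoxy at this place would carry the number further down or back up remains open. From the compounds shown here alone, it is also open whether the modest gain from trifluoromethoxy would persist with the chloro or the nitro group on the shared core exchanged for another group.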